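This account rests on a few compounds, and the source may have more. Where it says the series, first, only, none or still open, it means among the compounds named here.

Measured compounds:

Compound 1, `COc1ccc(C(=O)C2=C(O)C(=O)N(c3ccc(-c4ccon4)cc3)C2c2ccccc2OC)cc1`: 19.9%
Compound 2, `COc1ccc(C(=O)C2=C(O)C(=O)N(c3ccc(-c4ccon4)cc3)C2c2ccccc2OCCO)cc1`: 9%
Compound 3, `COc1ccccc1C1C(C(=O)C(C)C)=C(O)C(=O)N1c1ccc(-c2ccsc2)cc1`: 20%

All three values come from an ADME assay on the whole organism (Rattus norvegicus) for pharmacokinetics, at a dose of 1 mg/kg by the oral route; a higher number here means that a larger share of the oral dose reaches the circulation, a lower number that a smaller share of the oral dose reaches the circulation. In this assay compound 1 gives 19.9% and compound 2 gives 9%. The two differ in one place, (hydroxymethyl in place of hydrogen on a saturated chain carbon bound to an oxygen on an aromatic ring), and that change made a step of a number 10.9 percentage points lower from compound 1 to compound 2 (beyond the scatter). Compound 3 gives 20% in this assay; its value and that of compound 1 lie within the scatter of each other. The difference between the core of compound 3 and the core of compound 1 is not broken down here.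

Compound 4, `CC(C)C(=O)C1=C(O)C(=O)N(c2ccc(-c3ccsc3)cc2)C1c1ccccc1OCCO`, is not yet measured in this assay. It differs from compound 3 by hydroxymethyl in place of hydrogen on a saturated chain carbon bound to an oxygen on an aromatic ring, the same change that runs from compound 1 to compound 2, at the same kind of place. Within the data shown here, with only the one earlier pair to go on, a step of similar size is expected for compound 4, a number 10 percentage points lower from compound 3 to compound 4 (within the scatter), resting on the earlier step of a number 10.9 percentage points lower from compound 1 to compound 2 (beyond the scatter) from a starting value close to that of compound 3. Compound 4 is therefore estimated at 10% in this assay, within a band from 4% to 18%.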

Compound 4, oral bioavailability: 40.8%
Beside the measured number, compound 4's estimate is 30.8 percentage points below it, outside the stated range (above it).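

In this assay, the change from methoxy to 2-hydroxyethoxy gives a number 20.8 percentage points higher from compound 3 to compound 4 (beyond the scatter). The change therefore does not carry a fixed direction or size from one core to the other in this series: the same change on two cores in this assay, a number 10.9 percentage points lower (beyond the scatter) from compound 1 to compound 2 and a number 20.8 percentage points higher (beyond the scatter) from compound 3 to compound 4, 31.7 percentage points apart, beyond the scatter of two such steps

Among these compounds, what this does not show is which difference between the two cores goes with the reversal, as those differences are not broken down here, and with only one pair on each core it gives neither an explanation nor a rule for any further core.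

The compounds shown leave open whether a longer chain such as 3-hydroxypropoxy, or an amine such as 2-aminoethoxy or a carboxylic acid such as carboxymethoxy in place of 2-hydroxyethoxy, would follow the step on the core of compound 1 or the step on the core of compound 3. They also leave open which parts of the two cores would have to be exchanged, one at a time, for the step to change direction.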